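The compounds below may be only part of what the source reports. "The series", "measured", "known", "first", "only" and "open" are said of these compounds alone.

Going by the values given here, in a functional assay on HL-60 cells (Homo sapiens) for antiproliferative activity (on this read-out higher numbers stand for weaker inhibition and lower numbers for stronger inhibition), compound 1 (`COc1ccc(-c2snnc2-c2cc(OC)c(OC)c(OC)c2)cc1O`) gives 1.5 nM as the only number so far, so it holds no rank. Compound 2 (`COc1cc(-c2nnsc2-c2ccc(F)cc2)cc(OC)c1OC`) is recorded as "not determined" (no result reported) and offers no comparison. Compound 3 (`COc1ccc(-c2snnc2-c2cc(OC)c(OC)c(OC)c2)cc1N`) differs from compound 1 at one place (amino in place of hydroxy on an aromatic carbon) with amino in place of hydroxy on an aromatic carbon, ortho to a methoxy group. Among the compounds with values here, no measured pair in this assay shows this exchange, so only a small loss is expected, perhaps nothing beyond the scatter. The estimated step is a 2.0-fold higher number from compound 1 to compound 3 (0.30 log units; within the scatter) for now. For compound 3 the expected value is 3 nM (0.8 nM to 15 nM).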

Compound 3, half-maximal inhibitory concentration: 1.8 nM
Beside the measured number, compound 3's estimate is 1.7-fold (0.22 log units) above it; the range from low to high includes it.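

In this assay, amino in place of hydroxy on this aromatic carbon, ortho to a methoxy group, gives a 1.2-fold higher number from compound 1 to compound 3 (0.08 log units; within the scatter) and so shows that the position tolerates this exchange without a change beyond the scatter. The exchange leaves the counts of hydrogen-bond donors and acceptors as they were, and the read-out stays level with them. Nothing at hand accounts for the two groups reading alike. The compounds shown leave open how a carboxylic acid, an acetamide or a longer chain would read at this position. From the compounds shown here alone, whether the match between amino and hydroxy holds on other cells also remains open.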